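Lipid-thioether amide series: agonism at Toll-like receptor 2

A few compounds are considered here, and "the series" means these few. Any claim that something is new, unique, unknown or untested is made for them only; others in the source may bear on it.

Measured so far:
compound 1, `CCCCCCCCCCCC(=O)OC[C@H](CSC[C@@H](N)C(=O)NC1(CO)CC1)OC(=O)CCCCCCCCCCC`, 265 nM
compound 2, `CCCCCCCCCCCC(=O)OC[C@H](CSC[C@@H](N)C(=O)NC(C)c1ccc(O)cc1)OC(=O)CCCCCCCCCCC`, 2890 nM

Going by the values given here, in an assay on HEK293 cells for agonist activity at Toll-like receptor 2 (Homo sapiens) (on this read-out lower numbers stand for an effect already at smaller amounts and higher numbers for an effect only at larger amounts of compound), compound 2 stands at the highest of the two numbers known; its nearest neighbour is compound 1, and the step of an 11-fold higher number from compound 1 to compound 2 (1.04 log units; beyond the scatter) is the only measured comparison. Compound 3, `CCCCCCCCCCCC(=O)OC[C@H](CSC[C@@H](N)C(=O)NCCCCN)OC(=O)CCCCCCCCCCC`, has not been measured. It differs from compound 2 in a single place: 4-aminobutyl in place of 1-(4-hydroxyphenyl)ethyl on an amide-type nitrogen.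

Among the compounds with values here, only one measured step bears on this change. The step of an 11-fold higher number from compound 1 to compound 2 (1.04 log units; beyond the scatter) shows that swapping the group on the amide-type nitrogen can move the number by a large amount. Compound 3 carries 4-aminobutyl on that nitrogen, again a group without a ring, while the 1-(4-hydroxyphenyl)ethyl of compound 2 leaves. Given that the 1-(hydroxymethyl)cyclopropyl of compound 1 went with a lower number than the 1-(4-hydroxyphenyl)ethyl of compound 2, a move back toward a lower number is expected for compound 3, though the size is uncertain with one step as a guide. The expected step is a 6.4-fold lower number from compound 2 to compound 3 (0.81 log units; beyond the scatter). Compound 3 is therefore estimated at 450 nM, within a range from 110 nM to 1800 nM.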

Compound 3, half-maximal effective concentration: 1040 nM
Estimate against measurement, compound 3: 2.3-fold (0.36 log units) below; measured number inside the range.
By their numbers in this assay, from the lowest: compound 1; then compound 3; then compound 2.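

In this assay, the 4-aminobutyl group takes the middle place of the three groups on the amide-type nitrogen: a 2.8-fold lower number from compound 2 to compound 3 (0.44 log units; beyond the scatter), and a 3.9-fold higher number from compound 1 to compound 3 (0.59 log units; beyond the scatter), with both steps modest but beyond the usual scatter. The position therefore gives graded numbers across these three groups, not a simple split into two levels. Removing the six-membered aromatic ring of 1-(4-hydroxyphenyl)ethyl does not by itself reach the level of compound 1, since the ring-free 4-aminobutyl group still stands above the 1-(hydroxymethyl)cyclopropyl group; no data at hand explain this order.

The compounds shown leave open whether the amine must be present on this chain, which 4-hydroxybutyl or plain butyl would test, and whether chain length matters, which 3-aminopropyl or 5-aminopentyl would test. They also leave open whether the cyclopropyl ring or the hydroxymethyl of compound 1 goes with its lower number, a question that 2-hydroxyethyl or 1-(hydroxymethyl)cyclobutyl would address.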